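The source may report more compounds than this note shows. Statements on the series, on what has been measured and on what is new or still open speak of the compounds shown alone.

Measured compounds:
compound 1 `CC/C(=C\c1ccc(Cl)cc1)C(=O)/C=C/c1ccc(Cl)cc1` — 28300 nM
compound 2 `COc1ccc(/C=C(\C)C(=O)/C=C/c2ccccc2F)cc1` — 81200 nM
compound 3 `COc1ccc(/C=C(\C)C(=O)/C=C/c2ccc(F)cc2)cc1` — 68100 nM

In an ADME assay on Vero cells (Chlorocebus sabaeus) for cytotoxicity, read by MTT assay, with a stated time of 72 h (on this read-out lower numbers stand for higher toxicity in this test and higher numbers for lower toxicity in this test), compound 1 gives the lowest number of the three, beyond the scatter from both compound 2 and compound 3. Compound 4 `CC/C(=C\c1ccc(Cl)cc1)C(=O)/C=C/c1ccc(C=O)cc1` differs from compound 1 in one place: formyl in place of chloro on an aromatic carbon. Going by the values given here, no measured pair exchanges a ring substituent of this kind; the only single-change step, a 1.2-fold lower number from compound 2 to compound 3 (0.08 log units; within the scatter), moves a fluorine on the other ring and stays within the scatter, so it bears on the present change only loosely. Nothing in the series points to a large move in this assay in either direction. Compound 4 is therefore expected near compound 1, with the step of a 1.2-fold higher number from compound 1 to compound 4 (0.07 log units; within the scatter) treated as uncertain. The estimate for compound 4 is 33000 nM, within 12000 nM to 90000 nM.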

Compound 4, half-maximal cytotoxic concentration: 46900 nM
Beside the measured number, compound 4's estimate is 1.4-fold (0.15 log units) below it; the measured number falls inside the stated range.
By their numbers in this assay, from the lowest: compounds 1, 4, 3 and 2 (each within the scatter of the next, the first and the last beyond it).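

Formyl in place of chloro on an aromatic carbon, para to a large group, gives a 1.7-fold higher number from compound 1 to compound 4 (0.22 log units; within the scatter) in this assay. Going by these compounds alone, this is the first direct reading at this position: exchanging chloro for formyl, which brings one hydrogen-bond acceptor, does not separate the two compounds in this test. Nothing measured here offers an explanation for this result.

On these data alone, whether an amine or a carboxylic acid on this carbon would also stay within the scatter of compound 1 remains open. So does the effect of the same exchange on the other ring of compound 1.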